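Cyclopropyl carbonyl on the pyrrolidine nitrogen of the shared core

This account rests on a few compounds, and the source may have more. Where it says the series, first, only, none or still open, it means among the compounds named here.

Three compounds of this series have numbers in an ADME assay (Canis lupus familiaris, strain Beagle) for metabolic stability; a higher number here means that the compound lasts longer, a lower number that the compound disappears faster. Compound 1 `CCC(=O)N1CC[C@H](Oc2ncnc3c2nc(-c2cnc(C)nc2)n3CC)C1` gives 3.9 h. Compound 2 `CCn1c(-c2cnc(C)nc2)nc2c(N[C@H]3CCN(C(=O)[C@H]4C[C@@H](OC)C4)C3)ncnc21` gives 4.3 h. Compound 3 `CCn1c(-c2cnc(C)nc2)nc2c(N[C@H]3CCN(C(=O)N4CC(OC)C4)C3)ncnc21` gives 1.7 h, the lowest of the three; compound 1 is the nearer of the other two and compound 2 the further. Going by the values given here, the single one-place step among them is a 2.5-fold lower number from compound 2 to compound 3 (0.40 log units; beyond the scatter).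

Compound 4 `CCn1c(-c2cnc(C)nc2)nc2c(N[C@H]3CCN(C(=O)C4CC4)C3)ncnc21` has not been measured in this assay. It differs from compound 3 by cyclopropyl in place of 3-methoxyazetidin-1-yl on a carbonyl carbon. Among the compounds with values here, only the step from compound 2 to compound 3 bears on this change, and it ran in the lowering direction; partly reversing it, a modest rise is expected, a 2.1-fold higher number from compound 3 to compound 4 (0.31 log units; beyond the scatter). For compound 4 the estimate in this assay is 3.5 h, within 1.8 h to 7 h.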

Compound 4, half-life: 4.7 h
For compound 4 the middle estimate is 1.3-fold (0.13 log units) below the measured one, within the range that was stated.
By their numbers in this assay, from the lowest: compound 3; then compounds 1, 2 and 4 (each within the scatter of the next).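

Against 3-methoxyazetidin-1-yl on the carbonyl carbon, cyclopropyl also gives a longer-lasting compound in this assay, with a 2.8-fold higher number from compound 3 to compound 4 (0.44 log units; beyond the scatter), so the low number of compound 3 now stands out against two other groups. Cyclopropyl and 3-methoxycyclobutyl cannot be told apart, with a 1.1-fold higher number from compound 2 to compound 4 (0.04 log units; within the scatter), despite their different sizes. Nothing available explains the lower number of compound 3.

Still open, from the compounds shown here alone, is whether an unsubstituted azetidin-1-yl would keep that lower number, which would separate the ring nitrogen from the methoxy group. A dimethylamino group on the same carbonyl carbon would test an amide-type nitrogen without any ring.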